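This account rests on a few compounds, and the source may have more. Where it says the series, first, only, none or still open, it means among the compounds named here.

Among the measured compounds shown here, compound 2 `Cc1ccc2[nH]c(=O)c(-c3nc4cc(Cl)ccc4[nH]3)cc2c1` holds the only number in a functional assay on BEL-7404 cells for cytotoxicity against BEL-7404 tumor cell line (Homo sapiens), read by MTT assay, with a stated time of 48 h (a lower number here means a stronger inhibitor, a higher number a weaker inhibitor), where it gives 39000 nM. In this assay compound 1 `Cc1ccc2[nH]c(=O)c(-c3nc4cc([N+](=O)[O-])ccc4[nH]3)cc2c1` gives > 100000 nM, which is a limit of the measurement and not a number. For the measured compounds named here, the one measured step, an at least 2.5-fold lower number from compound 1 to compound 2 (0.40 log units; beyond the scatter), swaps one group for another at the same place. Compound 3 `Cc1ccc2[nH]c(=O)c(-c3nc4cc(Br)ccc4[nH]3)cc2c1` differs from compound 2 by bromo in place of chloro on an aromatic carbon. Going by the values given here, no measured step exchanges one halogen for another, so that step is only a loose guide, and the change from compound 2 to compound 3 is expected to stay within the scatter, as a 1.2-fold lower number from compound 2 to compound 3 (0.09 log units; within the scatter). Compound 3 is therefore estimated at 32000 nM, between 12000 nM and 85000 nM.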

Compound 3, half-maximal inhibitory concentration: > 100000 nM
Compound 3 was reported as a limit (the forecaster's own chance of this, stated with the estimate: 12%); middle value at least 3.1-fold (0.49 log units) away from the limit.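

In this assay, bromo in place of chloro gives an at least 2.5-fold higher number from compound 2 to compound 3 (0.40 log units; beyond the scatter), so at this aromatic carbon one halogen cannot be assumed to stand in for another. Among the three groups shown, only chloro gives a value that is a number, at 39000 nM for compound 2. The step between compound 1 and compound 3 cannot be read, as both values are limits of the assay: the limit of > 100000 nM in this assay, at which 2 of the 3 values shown sit.

From the compounds shown here alone, whether fluoro, a methoxy group or an amine at this carbon would give a number remains open. So does how far compound 1 and compound 3 actually lie from compound 2.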